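Cytotoxicity of a Pyridinylmethyl Analogue, Before Measurement

This account rests on a few compounds, and the source may have more. Where it says the series, first, only, none or still open, it means among the compounds named here.

Compound 1 `CS(=O)(=O)Nc1ccc2c(c1)S(=O)(=O)C=C(c1c(O)c3cc(F)ccc3n(Cc3ccccc3)c1=O)N2` is known in an ADME assay on 2209-23 cells (Homo sapiens) for cytotoxicity, read by WST assay (a higher number here means that more compound is tolerated, a lower number that less compound is tolerated), only as a limit: compound 1 gives > 50000 nM, which marks the edge of the assay rather than a number. Compound 2 `COc1cc(Cn2c(=O)c(C3=CS(=O)(=O)c4cc(NS(C)(=O)=O)ccc4N3)c(O)c3cc(F)ccc32)ccc1F` is likewise reported in this assay only as a limit, at > 50000 nM. The step that the two limits leave unreadable from compound 1 to compound 2 therefore cannot be read, because both values rest at the limit of > 50000 nM in this assay, at which 2 of the 2 values shown sit. Compound 3 `CS(=O)(=O)Nc1ccc2c(c1)S(=O)(=O)C=C(c1c(O)c3cc(F)ccc3n(Cc3ccccn3)c1=O)N2` has not yet been measured in this assay. It differs from compound 2 in a single place: pyridin-2-yl in place of 4-fluoro-3-methoxyphenyl on a saturated chain carbon bound to an aromatic nitrogen. Within the data shown here, the one measured step at the same place, from compound 1 to compound 2, is unreadable, so no size can be inferred for the new exchange; the two values shown give no sign of a readable change. The expected step in this assay is a step that the limit leaves unreadable from compound 2 to compound 3, that is, none beyond the scatter. Compound 3 is accordingly estimated at 60000 nM, with a range from 30000 nM to 120000 nM.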

Compound 3, half-maximal cytotoxic concentration: > 50000 nM
Compound 3: no number, only a limit (the forecaster's own chance of this, stated with the estimate: 85%); the middle value does not contradict the limit.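

In this assay compound 3 gives > 50000 nM, which is a limit and not a number. No step among compound 1, compound 2 and compound 3 can be read, because all three rest at the same limit: the limit of > 50000 nM in this assay, at which 3 of the 3 values shown sit.

The compounds shown leave open whether phenyl, 4-fluoro-3-methoxyphenyl and pyridin-2-yl at this place differ at all in this assay.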